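Replacing a Trifluoromethylphenyl Group with a Furan Ring

A few compounds are considered here, and "the series" means these few. Any claim that something is new, unique, unknown or untested is made for them only; others in the source may bear on it.

Of the compounds shown here, two sharing one core have been measured so far. Compound 1 `N#Cc1ccc(OCc2ccsc2)cc1OC(C(=O)O)c1ccccc1Cl` gives 17 nM in an assay on A10 cells for antagonist activity at Endothelin-1 receptor (Rattus norvegicus); on this read-out higher numbers stand for weaker inhibition and lower numbers for stronger inhibition. Compound 2 `N#Cc1ccc(OCc2ccsc2)cc1OC(C(=O)O)c1ccccc1C(F)(F)F` gives 53 nM in this assay. These two differ only on one aromatic carbon, and that change produced a 3.1-fold higher number from compound 1 to compound 2 (0.49 log units; beyond the scatter), a modest weakening. For the measured compounds named here, compound 2 therefore stands at the higher of the two numbers, with compound 1 as its only neighbour.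

Compound 3 `N#Cc1ccc(OCc2ccsc2)cc1OC(C(=O)O)c1ccco1` has not yet been measured. It differs from compound 2 by furan-2-yl in place of 2-(trifluoromethyl)phenyl on a saturated chain carbon bound to a carbonyl carbon and an oxygen on an aromatic ring. Going by the values given here, no measured step covers this kind of exchange: the single known step only swaps one substituent on the six-membered ring while the ring itself stays, so it is at best a weak guide here. With only a modest step on record and a larger structural change ahead, the expectation is a step of uncertain direction and modest size, most likely a further weakening. Compound 3 is expected to give 110 nM in this assay, within a range from 20 nM to 600 nM, which corresponds to an expected step of a 2.1-fold higher number from compound 2 to compound 3 (0.32 log units; beyond the scatter).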

Compound 3, half-maximal inhibitory concentration: 2400 nM
Estimate against measurement, compound 3: 22-fold (1.34 log units) below, outside the stated range (above it).
By their numbers in this assay, from the lowest: compound 1; then compound 2; then compound 3.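

Until now, this position had seen only a swap of one substituent on a six-membered ring that stayed in place, and that swap had a modest effect. Exchanging the whole ring has a far larger effect: in this assay, furan-2-yl in place of 2-(trifluoromethyl)phenyl gives a 45-fold higher number from compound 2 to compound 3 (1.66 log units; beyond the scatter) and furan-2-yl in place of 2-chlorophenyl gives a 140-fold higher number from compound 1 to compound 3 (2.15 log units; beyond the scatter) on the same read-out, so the group on this saturated chain carbon matters much more than the choice between chloro and trifluoromethyl suggested. The entering ring differs from both leaving groups in several ways at once, including ring size, heavy-atom count and a ring oxygen that adds a hydrogen-bond acceptor, and nothing available here shows which of these differences accounts for the loss of inhibition.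

The compounds shown leave open whether the six-membered ring itself or its substituent carries most of the effect, a question that a plain phenyl group at this place could help to answer. They also leave open whether a furan-2-yl ring bearing a methyl or a chloro group would regain any of the lost inhibition.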